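Notes on the step from compound 2 to compound 3

A few compounds are considered here, and "the series" means these few. Any claim that something is new, unique, unknown or untested is made for them only; others in the source may bear on it.

Measured so far in an ADME assay on A549 cells (Homo sapiens) for cytotoxicity, read by LDH release, with a stated time of 15 h; a higher number here means that more compound is tolerated, a lower number that less compound is tolerated:
- compound 1 `O=C(Nc1ccc(NCCCO)cc1Cl)c1cc(Cl)ccc1O` | "not determined" (no result reported)
- compound 2 `CC(C)Nc1ccc(NC(=O)c2cc(Cl)ccc2O)c(Cl)c1` | 82700 nM

Within the data shown here, compound 2 holds the only number, and compound 1 has no result. Among the measured compounds shown here, compound 2 therefore cannot be ranked against any other compound, and no step between measured compounds is available.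

Compound 3 `CCCCCCC(C)Nc1ccc(NC(=O)c2cc(Cl)ccc2O)c(Cl)c1` awaits measurement. It differs from compound 2 by pentyl in place of hydrogen on a saturated chain carbon, two bonds along the chain from a nitrogen on an aromatic ring, which reads as isopropyl to 1-methylheptyl when cut one bond further out. For the measured compounds named here, no measured pair here shows what such a change does, and the expectation rests on judgement alone. A moderate step beyond the scatter is expected, toward less compound tolerated, and the range is kept wide. Compound 2 at 82700 nM is the sole anchor.

The expected change is a 3.3-fold lower number from compound 2 to compound 3 (0.52 log units; beyond the scatter), given here as an estimate. In this assay compound 3 is estimated at 25000 nM, with an expected range from 6000 nM to 80000 nM for now.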

Compound 3, half-maximal cytotoxic concentration: 18600 nM
Compound 3: the middle estimate sits 1.3-fold (0.13 log units) above what was measured, and the stated range covers the measured number.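

In this assay, the series now has its first readable step: isopropyl to 1-methylheptyl, with pentyl in place of hydrogen on a saturated chain carbon, two bonds along the chain from a nitrogen on an aromatic ring, gives a 4.4-fold lower number from compound 2 to compound 3 (0.65 log units; beyond the scatter). This shows that the change at this position moves the number beyond the usual scatter and toward less compound tolerated, though the direction rests on a single pair and compound 1 adds no comparison. Nothing shown accounts for the shift, so it stands as an observation without a cause.

One step cannot show whether the number falls steadily with added carbon or changes abruptly at some chain size, and an ethyl or butyl group in place of the pentyl, or a longer chain such as octyl, would help separate those readings. Going by these compounds, it also remains open whether a chain carrying a carboxylic acid or an amine would follow the same direction as the pentyl change in this assay.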